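The source may report more compounds than this note shows. Statements on the series, on what has been measured and on what is new or still open speak of the compounds shown alone.

Compound 3 `Cn1ccc2c(Oc3ccc(NC(=O)c4nn(-c5ccc(Cl)c(F)c5)ccc4=O)cc3F)ccnc21` stands in a functional assay on A549 cells (Homo sapiens) for cytotoxicity, read by MTT assay, with a stated time of 72 h (a lower number here means a stronger inhibitor, a higher number a weaker inhibitor), at the edge of what the assay reports: it gives > 60000 nM, which is a limit rather than a number. Compound 2 `COc1ccc(-n2ccc(=O)c(C(=O)Nc3ccc(Oc4ccnc5c4ccn5C)c(F)c3)n2)cc1` likewise gives only a limit, > 60000 nM. The step that the two limits leave unreadable from compound 2 to compound 3 is thus unreadable. Among the measured compounds shown here, compound 1 `O=C(Nc1ccc(Oc2ccnc3[nH]ccc23)c(F)c1)c1nn(-c2ccc(Cl)c(C(F)(F)F)c2)ccc1=O` is the one compound here with a number, 13400 nM. Compound 4 `Cn1ccc2c(Oc3ccc(NC(=O)c4nn(-c5ccc(Cl)c(C(F)(F)F)c5)ccc4=O)cc3F)ccnc21` differs from compound 3 by trifluoromethyl in place of fluoro on an aromatic carbon. No measured step matches this change; the only step shown is unreadable, and the limit of > 60000 nM in this assay, at which 2 of the 3 values shown sit, holds two of the three values. Compound 1, which carries the same trifluoromethyl-bearing group, gives 13400 nM. On that basis compound 4 is expected near 40000 nM, between 10000 nM and 200000 nM. The expected step of an at least 1.5-fold lower number from compound 3 to compound 4 (0.17 log units; that floor lies within the scatter) cannot be sized from a limit.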

Compound 4, half-maximal inhibitory concentration: 17700 nM
For compound 4 the middle estimate is 2.3-fold (0.35 log units) above the measured one; the measured number falls inside the stated range.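

In this assay, trifluoromethyl in place of fluoro, ortho to a chloro group, gives an at least 3.3-fold lower number from compound 3 to compound 4 (0.53 log units; beyond the scatter), the first readable effect of a change at this place. Replacing 4-methoxyphenyl with 4-chloro-3-(trifluoromethyl)phenyl gives an at least 3.3-fold lower number from compound 2 to compound 4 (0.53 log units; beyond the scatter). Methyl in place of hydrogen on an aromatic nitrogen gives a 1.3-fold higher number from compound 1 to compound 4 (0.12 log units; within the scatter), so with this aryl group the methyl makes no readable difference.

From the compounds shown here alone, the full size of the first two steps stays open, and the step from compound 2 to compound 3 cannot be read: the limit of > 60000 nM in this assay, at which 2 of the 4 values shown sit. Going by these compounds, whether a nitrile or a bromo group at this place would match trifluoromethyl also remains open.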